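The compounds below may be only part of what the source reports. "The series", "measured", "known", "first", "only" and "open" are said of these compounds alone.

Measured in a functional assay on A549 cells (Homo sapiens) for antiproliferative activity, read by MTT assay; a lower number here means a stronger inhibitor, a higher number a weaker inhibitor:
- compound 1 `COc1ccc(-c2ccnc(Nc3ccc(Cl)cc3Cl)n2)cc1`: 7330 nM
- compound 2 `Clc1ccc(Nc2nccc(-c3ccc(Br)cc3)n2)c(Cl)c1`: 3780 nM
- compound 3 `Cc1ccc(-c2ccnc(Nc3ccc(Cl)cc3Cl)n2)cc1`: not yet measured

Compound 2, at 3780 nM, lies within the scatter of compound 1, so neither stands apart on these two numbers. The next change, to compound 3, is methyl in place of bromo on an aromatic carbon, giving 4-methylphenyl in place of 4-bromophenyl. Among the measured compounds shown here, one measured step bears on it: bromo in place of methoxy, a 1.9-fold lower number from compound 1 to compound 2 (0.29 log units; within the scatter), which stays within the scatter. On that single step, no change beyond the scatter is expected in this assay. The expected step is a 1.2-fold higher number from compound 2 to compound 3 (0.08 log units; within the scatter). Compound 3 is estimated at 4500 nM, with an expected range of 2200 nM to 9000 nM.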

Compound 3, half-maximal inhibitory concentration: 164000 nM
Compound 3: middle estimate off by 36-fold (1.56 log units), on the low side; the whole stated range lies below it.
By their numbers in this assay, from the lowest: compounds 2 and 1 (each within the scatter of the next); then compound 3.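

In this assay this aromatic carbon proves sensitive to the choice of group: a 43-fold higher number from compound 2 to compound 3 (1.64 log units; beyond the scatter) with methyl in place of bromo, and a 22-fold higher number from compound 1 to compound 3 (1.35 log units; beyond the scatter) with methyl in place of methoxy. Compound 1 and compound 2 lie within the scatter of each other, so among these three only compound 3 stands apart, a separation the first pair gave no sign of. Nothing available accounts for this weaker result.

On these data alone, whether the loss is particular to methyl remains open. A chlorine, an ethyl chain, a hydroxyl or an amine at this carbon would show how far it extends.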